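Swapping One Amide Group on Compound 1

This account rests on a few compounds, and the source may have more. Where it says the series, first, only, none or still open, it means among the compounds named here.

Going by the values given here, in a functional assay on L1210 cells (Mus musculus) for cytotoxicity (on this read-out lower numbers stand for stronger inhibition and higher numbers for weaker inhibition), compound 1 (`O=C(/C=C/C(=O)N1C/C(=C\c2ccc([N+](=O)[O-])cc2)C(=O)/C(=C/c2ccc([N+](=O)[O-])cc2)C1)Nc1ccc(Cl)c(Cl)c1`) gives 1700 nM, the lower of the two numbers available so far. Compound 2 (`Cc1ccc(NC(=O)/C=C/C(=O)N2C/C(=C\c3ccccc3)C(=O)/C(=C/c3ccccc3)C2)cc1C`) gives 31000 nM, a higher number and a gap well beyond the usual scatter. The next molecule, compound 3 (`Cc1ccc(NC(=O)/C=C/C(=O)N2C/C(=C\c3ccc([N+](=O)[O-])cc3)C(=O)/C(=C/c3ccc([N+](=O)[O-])cc3)C2)cc1`), keeps the core of compound 1 and changes one group, with 4-methylphenyl in place of 3,4-dichlorophenyl on an amide-type nitrogen. Among the compounds with values here, no measured pair shows this change on its own, so its size remains uncertain. Within the data shown here, the only other number, compound 2 at 31000 nM, lies on the higher side, and that tilts the expectation towards weaker inhibition. The expected change is modest, an estimated 2.1-fold higher number from compound 1 to compound 3 (0.31 log units; beyond the scatter). For compound 3 the estimated value is 3500 nM, with a likely range of 1200 nM to 12000 nM.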

Compound 3, half-maximal inhibitory concentration: 4400 nM
Compound 3: the middle estimate sits 1.3-fold (0.10 log units) below what was measured; the measured number falls inside the stated range.
By their numbers in this assay, from the lowest: compound 1; then compound 3; then compound 2.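

Going by these compounds alone, this is the first direct reading of a change at this position: in this assay, with the core of compound 1 kept, placing 4-methylphenyl instead of 3,4-dichlorophenyl on the amide-type nitrogen gives a 2.6-fold higher number from compound 1 to compound 3 (0.41 log units; beyond the scatter) in a single step. The group on this nitrogen therefore does affect the read-out, but this swap shifts it only modestly and weakens inhibition rather than abolishing it. No measurement here explains why the number rises.

The swap removes both chlorines and adds a methyl at once, so the compounds shown cannot separate the loss of chlorine from the gain of methyl. Going by these compounds, it also remains open how this position would respond to a plain phenyl, a single chlorine, or a ring carrying an amine or a carboxylic acid.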